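The source may report more compounds than this note shows. Statements on the series, on what has been measured and on what is new or still open speak of the compounds shown alone.

Compound 1 `CCOc1cc(=O)oc2cc(OCc3cccc(Cl)c3)ccc12` gives 115 nM in an assay on isolated protein (strain Sprague-Dawley) for inhibition of Amine oxidase [flavin-containing] B (Rattus norvegicus), read by spectrophotometry, with a stated time of 5 min; a lower number here means a stronger inhibitor, a higher number a weaker inhibitor.
Compound 2 `COCOc1cc(=O)oc2cc(OCc3cccc(Cl)c3)ccc12` gives 100 nM in this assay.

Within the data shown here, compound 2 holds the lowest of the two numbers, but its only neighbour is compound 1, and the step of a 1.2-fold lower number from compound 1 to compound 2 (0.06 log units; within the scatter) lies within the scatter, so the two compounds cannot be ordered. Compound 3 `CC(=O)COc1cc(=O)oc2cc(OCc3cccc(Cl)c3)ccc12` differs from compound 2 by acetyl in place of methoxy on a saturated chain carbon bound to an oxygen on an aromatic ring. Among the measured compounds shown here, the one measured step that bears on this change is a 1.2-fold lower number from compound 1 to compound 2 (0.06 log units; within the scatter), which also replaced a group on a saturated chain carbon bound to an oxygen on the aromatic ring and moved the number hardly at all. For the measured compounds named here, no measured compound shows what a carbonyl at that place does, so the expectation for this assay is a small step at most, with no clear direction beyond the scatter. Compound 3 is therefore estimated at 130 nM, with a range from 50 nM to 350 nM. This amounts to an expected step of a 1.3-fold higher number from compound 2 to compound 3 (0.11 log units; within the scatter).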

Compound 3, half-maximal inhibitory concentration: 26.9 nM
The estimate for compound 3 lay 4.8-fold (0.68 log units) above the measured number; measured number outside the range, below it.
By their numbers in this assay, from the lowest: compound 3; then compounds 2 and 1 (each within the scatter of the next).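

In this assay, the place on a saturated chain carbon bound to an oxygen on an aromatic ring turns out to respond to the group it carries: acetyl in place of methoxy gives a 3.7-fold lower number from compound 2 to compound 3 (0.57 log units; beyond the scatter), and acetyl in place of methyl gives a 4.3-fold lower number from compound 1 to compound 3 (0.63 log units; beyond the scatter). Methyl and methoxy could not be told apart here, so compound 3, with its added carbonyl, is the first compound to stand clear of the others, with the lower number. No evidence at hand speaks to what lies behind this step.

The compounds shown leave open whether the carbonyl or the whole 2-oxopropyl group carries the step, as neither a 2-hydroxypropyl chain, a longer ketone chain nor an amide appears at this place. On these data alone, whether the step holds without the chlorine on the shared core also stays open.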